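A few compounds are considered here, and "the series" means these few. Any claim that something is new, unique, unknown or untested is made for them only; others in the source may bear on it.

Of the compounds shown here, three sharing one core have been measured so far in a functional assay on MCF7 cells (Homo sapiens) for cytotoxicity, read by MTT assay, with a stated time of 48 h; on this read-out higher numbers stand for weaker inhibition and lower numbers for stronger inhibition. There compound 1 `O=C1/C(=C\c2ccc(O)cc2)S/C(=N/c2ccccc2)N1Cc1ccncc1` gives 18900 nM and compound 2 `CCOc1cc(/C=C2/S/C(=N/c3ccccc3)N(Cc3ccncc3)C2=O)ccc1O` gives 20100 nM while compound 3 `O=C1/C(=C\c2cccc(O)c2)S/C(=N/c2ccccc2)N1Cc1ccncc1` gives 43600 nM as the highest number of the three. Compound 4 `O=C1/C(=C\c2cccc(Cl)c2)S/C(=N/c2ccccc2)N1Cc1ccncc1` differs from compound 3 in a single exchange, chloro in place of hydroxy on an aromatic carbon, meta to a large group (chloro in place of hydroxy on an aromatic carbon). For the measured compounds named here, no measured step makes this exchange, so the evidence is indirect. Moving the hydroxy group gave a modest step (a 2.3-fold higher number from compound 1 to compound 3 (0.36 log units; beyond the scatter)), and the step to compound 3 from the ethoxy-bearing compound was also modest (a 2.2-fold higher number from compound 2 to compound 3 (0.34 log units; beyond the scatter)). Adding ethoxy stayed within the scatter (a 1.1-fold higher number from compound 1 to compound 2 (0.03 log units; within the scatter)). Changes on this ring have therefore moved the number only modestly, and compound 3 sits at the top of the measured values. A small shift toward a lower number is expected, with no change beyond the scatter, and the expected step is a 1.6-fold lower number from compound 3 to compound 4 (0.19 log units; within the scatter) in this set. Compound 4 is estimated at 28000 nM with an expected range from 11000 nM to 65000 nM.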

Compound 4, half-maximal inhibitory concentration: 29800 nM
Beside the measured number, compound 4's estimate is 1.1-fold (0.03 log units) below it; the range from low to high includes it.
By their numbers in this assay, from the lowest: compounds 1, 2, 4 and 3 (each within the scatter of the next, the first and the last beyond it).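

In this assay, the exchange of hydroxy for chloro on an aromatic carbon, meta to a large group, stays within the scatter (a 1.5-fold lower number from compound 3 to compound 4 (0.17 log units; within the scatter)), even though hydroxy counts one hydrogen-bond donor and one acceptor and chloro counts neither. Compound 4 also lies within the scatter of the two other compounds (a 1.5-fold higher number from compound 2 to compound 4 (0.17 log units; within the scatter); a 1.6-fold higher number from compound 1 to compound 4 (0.20 log units; within the scatter)), so replacing either of their substituted phenyl groups with 3-chlorophenyl produces no step beyond it. No available evidence accounts for this result.

On these data alone, whether an amine, a carboxylic acid or a longer chain such as propoxy at this place would move the number beyond the scatter remains open. Also open, as far as these compounds go, is whether chloro would read the same on the other aromatic carbons of this ring.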